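The compounds below may be only part of what the source reports. "The series", "measured", "known", "first", "only" and "open" are said of these compounds alone.

Compound 1 `CSc1ccccc1NC(=O)Nc1cc(C)nc2ccccc12`: > 25000 nM
Compound 2 `Cc1cc(NC(=O)Nc2ccccc2C(N)=O)c2ccccc2n1`: > 25000 nM

Both compounds were tested in an ADME assay on HepG2 cells (Homo sapiens) for cytotoxicity, with a stated time of 72 h; on this read-out lower numbers stand for an effect already at smaller amounts and higher numbers for an effect only at larger amounts of compound. There, compound 2 gives > 25000 nM, which is a limit of the assay and not a number. Compound 1 gives > 25000 nM, and this too is a limit.

Compound 3 `Cc1cc(NC(=O)Nc2ccccc2C(F)(F)F)c2ccccc2n1` keeps the rest of compound 2 and carries trifluoromethyl in place of carbamoyl on an aromatic carbon. For the measured compounds named here, the nearest guide is the one measured step, a step that the two limits leave unreadable from compound 1 to compound 2, which put carbamoyl in place of methylsulfanyl on an aromatic carbon. It offers no size to carry over, as neither end of it is a number. The other guide is the limit of > 25000 nM in this assay, at which 2 of the 2 values shown sit, which covers both compound 1 and compound 2. On that basis, no step beyond the usual scatter is expected, and the most likely result for compound 3 is another limit. The expected change is a number no higher from compound 2 to compound 3 (the limit leaves the size open). For compound 3 the estimated value is 25000 nM, with an expected range from 10000 nM to 50000 nM.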

Compound 3, half-maximal effective concentration: > 25000 nM
Compound 3 gave a limit, no number (the forecaster's own chance of this, stated with the estimate: 75%); the middle value sits exactly at the limit.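

With compound 3 also at a limit of the assay and not a number, neither step leading to it, from compound 1 or from compound 2, can be read. The compounds shown leave open how methylsulfanyl, carbamoyl and trifluoromethyl compare in this assay, as all three compounds stop at the same point: the limit of > 25000 nM in this assay, at which 3 of the 3 values shown sit.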